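The source may hold more compounds than are shown below. What is called first, only, known or untested is meant among the compounds shown, and "the series" means these compounds.

Measured so far:
compound 1 `CC(C)=Cc1sc(C(C)C)c(/C=C/[C@@H](O)C[C@@H](O)CC(=O)O)c1-c1ccc(F)cc1`, 15 nM
compound 2 `Cc1sc(C(C)C)c(/C=C/[C@@H](O)C[C@@H](O)CC(=O)O)c1-c1ccccc1`, 94 nM

In an assay on microsomes for inhibition of 3-hydroxy-3-methylglutaryl-coenzyme A reductase (Rattus norvegicus) (a higher number here means a weaker inhibitor, a lower number a stronger inhibitor), compound 1 gives 15 nM, the lower of the two numbers shown. Compound 2 gives 94 nM, a higher number, and the gap between the two lies beyond the usual scatter. Compound 3 `Cc1ccc(-c2sc(C(C)C)c(/C=C/[C@@H](O)C[C@@H](O)CC(=O)O)c2-c2ccc(F)cc2)cc1` is not yet measured. It differs from compound 1 in one place: 4-methylphenyl in place of 2-methylprop-1-en-1-yl on an aromatic carbon. Within the data shown here, no measured pair shows this change, so its effect cannot be read from the two compounds above. The change is expected to move the number little, so compound 3 is estimated at 20 nM, with a range from 6 nM to 65 nM, which means an expected step of a 1.3-fold higher number from compound 1 to compound 3 (0.12 log units; within the scatter).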

Compound 3, half-maximal inhibitory concentration: 9.7 nM
Estimate against measurement, compound 3: 2.1-fold (0.31 log units) above; the range from low to high includes it.
By their numbers in this assay, from the lowest: compounds 3 and 1 (each within the scatter of the next); then compound 2.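

On the aromatic carbon next to the ring sulfur, 4-methylphenyl can replace 2-methylprop-1-en-1-yl, giving a 1.5-fold lower number from compound 1 to compound 3 (0.19 log units; within the scatter) in this assay. This position therefore tolerates an added six-membered aromatic ring, and the two groups cannot be told apart in this measurement despite their different sizes. Nothing available explains why they read alike.

Going by these compounds, it remains open whether the position would also tolerate an amine, a carboxylic acid or a longer chain. It is equally unclear how a bare hydrogen there would compare.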